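This account rests on a few compounds, and the source may have more. Where it says the series, first, only, none or still open, it means among the compounds named here.

Three compounds of this series carry an arylpiperazine sulfonyl group on the shared core, and all three have been examined in an assay on CHO cells for displacement of a labelled ligand from adenosine receptor A2b (Homo sapiens), read by scintillation counting, with a stated time of 75 min, in the presence of a further agent that is not named here; a higher number here means a weaker inhibitor, a lower number a stronger inhibitor. Compound 1 `CCCn1c(=O)c2[nH]c(-c3ccc(S(=O)(=O)N4CCN(c5ccc(Cl)cc5)CC4)cc3)nc2n(CC)c1=O` gives 4.31 nM in this assay. Compound 2 `CCCn1c(=O)[nH]c2nc(-c3ccc(S(=O)(=O)N4CCN(c5ccccc5)C(C)C4)cc3)[nH]c2c1=O` gives 7.15 nM. Compound 3 `CCCn1c(=O)[nH]c2nc(-c3ccc(S(=O)(=O)N4CCN(c5ccc(I)cc5)CC4)cc3)[nH]c2c1=O` gives 0.159 nM, the lowest number of the three: compound 1 sits at a higher number beyond the scatter, and compound 2 further still, so compound 3 stands as the strongest inhibitor among those measured.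

The next compound, compound 4 `CCCn1c(=O)[nH]c2nc(-c3ccc(S(=O)(=O)N4CCN(c5ccccc5F)CC4)cc3)[nH]c2c1=O`, takes one step away from compound 3. The change is 2-fluorophenyl in place of 4-iodophenyl on an amine nitrogen in a ring. Among the compounds with values here, no pair of measured compounds differs in this one place alone, so the size of the step has no direct precedent. Still, both compounds that lack an iodine at that position, compound 1 and compound 2, return higher numbers, and that weighs on the expectation. Compound 4 is therefore expected to give a higher number than compound 3, with a step of a 19-fold higher number from compound 3 to compound 4 (1.28 log units; beyond the scatter) beyond the scatter. Taking that together, compound 4 is estimated at 3 nM, within a range from 0.6 nM to 15 nM.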

Compound 4, inhibition constant: 3.22 nM
For compound 4 the middle estimate is 1.1-fold (0.03 log units) below the measured one; the measured number falls inside the stated range.
By their numbers in this assay, from the lowest: compound 3; then compounds 4, 1 and 2 (each within the scatter of the next, the first and the last beyond it).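

In this assay, within the data shown here, the exchange of 4-iodophenyl for 2-fluorophenyl on the amine nitrogen in a ring gives the first direct reading at this position: a 20-fold higher number from compound 3 to compound 4 (1.31 log units; beyond the scatter) is a large step, so the number here is clearly sensitive to what the aryl group carries. The step arises although the two groups match in their counts, with the same number of heavy atoms, one six-membered aromatic ring of carbon only, no hydrogen-bond donors or acceptors and no net charge, so those counts alone do not set the number at this position. The halogen and its place on the ring change together in this one exchange, and nothing measured here offers a reason for the size of the step.

The compounds shown leave open whether the identity of the halogen or its place on the ring carries the step, a question that a 4-fluorophenyl or a 2-iodophenyl group at this position would separate. They also leave open how a substituent other than a halogen, such as a methoxy group or a nitrile on the same phenyl ring, would read in this assay against the iodine of compound 3.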